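The compounds below may be only part of what the source reports. "The series", "measured", "known", "first", "only" and "open" are said of these compounds alone.

Notes on the series. In a functional assay on CAKI-1 cells (Homo sapiens) for cytotoxicity (a higher number here means a weaker inhibitor of growth, a lower number a stronger inhibitor of growth), compound 1 `COc1ccc(/N=C/c2cc(OC)c(OC)c(OC)c2)cc1` gives > 100000 nM, which is a limit and not a number. Compound 2 `CCOc1ccc(/N=C/c2cc(OC)c(OC)c(OC)c2)cc1` gives > 100000 nM, also a limit. Compound 2 therefore has no readable value and stands at the limit of > 100000 nM in this assay, at which 2 of the 2 values shown sit.

Within the data shown here, the only measured step is a step that the two limits leave unreadable from compound 1 to compound 2, so no size can be carried forward from it. That step changes only the chain on the oxygen. Compound 3 `CCCc1ccc(/N=C/c2cc(OC)c(OC)c(OC)c2)cc1` instead replaces the whole group: propyl in place of ethoxy on an aromatic carbon. This puts propyl in place of ethoxy on an aromatic carbon, para to a large group, so the oxygen is lost.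

Among the measured compounds shown here, no measured step bears directly on this exchange, and the data give no direction for it. For the measured compounds named here, no step of definite size is therefore expected in this assay, and the likeliest result is another limit rather than a number. The expected step is an at least 1.2-fold lower number from compound 2 to compound 3 (0.09 log units; that floor lies within the scatter). For compound 3 the estimated value is 80000 nM, with an expected range from 20000 nM to 100000 nM.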

Compound 3, concentration for 50% growth inhibition: > 100000 nM
Compound 3 ended at the assay's limit; the forecaster's own chance of this, stated with the estimate: 70%; middle value at least 1.2-fold (0.09 log units) away from the limit.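

In this assay compound 3 gives > 100000 nM, a limit and not a number. No step among compound 1, compound 2 and compound 3 can be read, and all three stand together: the limit of > 100000 nM in this assay, at which 3 of the 3 values shown sit.

The compounds shown leave open how methoxy, ethoxy and propyl rank against one another for growth inhibition.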